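Notes on a small antiproliferative series

This account rests on a few compounds, and the source may have more. Where it says the series, first, only, none or still open, it means among the compounds named here.

Compound 1 `COc1cc(-c2ncnn2-c2ccc(Cl)c(Cl)c2)cc(OC)c1OC`: > 10000 nM
Compound 2 `COc1cc(-n2ncnc2-c2ccc(Cl)cc2)cc(OC)c1OC`: > 10000 nM

In a functional assay on HeLa cells (Homo sapiens) for antiproliferative activity, read by MTT assay, with a stated time of 72 h (a lower number here means a stronger inhibitor, a higher number a weaker inhibitor), compound 1 gives > 10000 nM, which is a limit of the assay rather than a number. Compound 2 gives > 10000 nM, again only a limit. Going by the values given here, both values sit at the limit of > 10000 nM in this assay, at which 2 of the 2 values shown sit, so compound 1 stands nowhere distinguishable from the rest of what has been measured, and no step between measured compounds can be counted. Compound 3 `COc1cc(-c2ncnn2-c2cccc(F)c2)cc(OC)c1OC` has not yet been measured. It differs from compound 1 by 3-fluorophenyl in place of 3,4-dichlorophenyl on an aromatic nitrogen. With both measured compounds at the limit, no step beyond the scatter is expected from this change, and any real shift in either direction would stay hidden under the limit. The estimate for compound 3 is 15000 nM, with a range from 5000 nM to 60000 nM. That estimate means an expected step that the limit leaves unreadable from compound 1 to compound 3, within the scatter, and most likely only another limit will be recorded.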

Compound 3, half-maximal inhibitory concentration: > 10000 nM
Compound 3 gave a limit, no number; the forecaster's own chance of this, stated with the estimate: 80%; the middle value is on the limit's open side.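

Going by these compounds alone, compound 3 gives > 10000 nM, a limit and not a number, and compound 1 also stands at a limit, so no step between compound 1 and compound 3 can be read. Still open is which change to the shared core, if any, would give a readable number in this assay: the limit of > 10000 nM in this assay, at which 3 of the 3 values shown sit.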